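Replacing a Thiophene with Dichlorophenyl: Solubility Outlook

The source may hold more compounds than are shown below. What is called first, only, known or untested is meant among the compounds shown, and "the series" means these compounds.

compound 1 `CCOC(=O)c1c(-c2cccs2)[nH]c2cc(OC)ccc2c1=O`: > 100000 nM
compound 2 `CCOC(=O)c1c(-c2ccc(Cl)cc2)[nH]c2cccc(OC)c2c1=O`: > 100000 nM
compound 3 `CCOC(=O)c1c(-c2ccccc2)[nH]c2cccc(OC)c2c1=O`: > 100000 nM

Three compounds share one core and differ only in the aromatic group attached to it. In a physicochemical assay for solubility, in phosphate buffer, at pH 7.4 (a lower number here means a less soluble compound, a higher number a more soluble compound), compound 1 gives > 100000 nM, which is a limit of the assay and not a number. Compound 2 likewise gives > 100000 nM, a limit. Compound 3 gives > 100000 nM, again a limit. Compound 1 therefore stands at the limit of > 100000 nM in this assay, at which 3 of the 3 values shown sit; all that is known is that it is at least this soluble, with no number to compare.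

Within the data shown here, the only change among measured compounds, a step that the two limits leave unreadable from compound 2 to compound 3, is unreadable for the same reason: both ends are limits, so no size or direction can be drawn from it.

Compound 4 `CCOC(=O)c1c(-c2ccc(Cl)c(Cl)c2)[nH]c2cc(OC)ccc2c1=O` differs from compound 1 by 3,4-dichlorophenyl in place of thiophen-2-yl on an aromatic carbon. Among the measured compounds shown here, no measured step bears on this change, so no direction beyond the scatter can be predicted from the data. Compound 4 is estimated at 60000 nM, within a range of 8000 nM to 150000 nM. The expected step of an at least 1.6-fold lower number from compound 1 to compound 4 (0.22 log units; that floor lies within the scatter) is thus an estimate with wide uncertainty, and another limit reading is quite possible.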

Compound 4, solubility: 17000 nM
Estimate against measurement, compound 4: 3.5-fold (0.55 log units) above, and the stated range covers the measured number.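

In this assay, putting 3,4-dichlorophenyl in place of thiophen-2-yl on this aromatic carbon, next to the ring nitrogen and ortho to the ethoxycarbonyl group, gives an at least 5.8-fold lower number from compound 1 to compound 4 (0.76 log units; beyond the scatter). One end of that step is a limit, so its printed size is only a floor and the real drop may be larger. Compound 4 is the first compound here to give a number rather than a limit, which gives this core a value that later changes can be compared with: the limit of > 100000 nM in this assay, at which 3 of the 4 values shown sit.

On these data alone, whether the drop comes from the phenyl ring itself or from its two chlorines stays open. Also open, as far as these compounds go, is how this assay would read with a carboxylic acid in place of the ethoxycarbonyl group, or with an amine in place of the 3,4-dichlorophenyl.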